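Solubility of an amide series: from methyl to a pyrrolidinyl chain

The source may report more compounds than this note shows. Statements on the series, on what has been measured and on what is new or still open speak of the compounds shown alone.

Measured compounds:
compound 1 `CNC(=O)c1ccncc1Nc1cc(-c2ccc3ccn(C)c3c2)c2nccnc2c1` 4 ug/mL
compound 2 `CN1CCC(NC(=O)c2ccncc2Nc2cc(-c3ccc4ccn(C)c4c3)c3nccnc3c2)CC1=O` 48 ug/mL
compound 3 `CN1CC(NC(=O)c2ccncc2Nc2cc(-c3ccc4ccn(C)c4c3)c3nccnc3c2)CCC1=O` 253 ug/mL

In a physicochemical assay for solubility, read by spectrophotometry, measured as kinetic solubility, at pH 8, tested at 500 uM (on this read-out higher numbers stand for higher solubility and lower numbers for lower solubility), compound 1 gives 4 ug/mL, the lowest of the three numbers; its nearest neighbour is compound 2 with 48 ug/mL, and compound 3 stands furthest with 253 ug/mL. The unmeasured compound 4 `CN1CCC(CNC(=O)c2ccncc2Nc2cc(-c3ccc4ccn(C)c4c3)c3nccnc3c2)C1` differs from compound 1 by 1-methylpyrrolidin-3-yl in place of hydrogen on a saturated chain carbon bound to an amide-type nitrogen.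

Within the data shown here, two measured steps bear on this change, since both also grow the group on the amide-type nitrogen of compound 1 into a saturated nitrogen-containing ring: a 12-fold higher number from compound 1 to compound 2 (1.08 log units; beyond the scatter) and a 63-fold higher number from compound 1 to compound 3 (1.80 log units; beyond the scatter). Among the measured compounds shown here, both are large and point upward, though the entering groups there are lactam rings, whereas in compound 4 a 1-methylpyrrolidin-3-yl ring enters on a saturated chain carbon, a change for which no measured pair exists. A large upward step is therefore expected, namely a 28-fold higher number from compound 1 to compound 4 (1.44 log units; beyond the scatter), of roughly the size of the smaller of those two measured steps or larger. Compound 4 is thus estimated to reach 110 ug/mL in this assay, with a range from 25 ug/mL to 250 ug/mL.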

Compound 4, solubility: 246 ug/mL
Beside the measured number, compound 4's estimate is 2.2-fold (0.35 log units) below it; measured number inside the range.
By their numbers in this assay, from the lowest: compound 1; then compound 2; then compounds 4 and 3 (each within the scatter of the next).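

In this assay the (1-methylpyrrolidin-3-yl)methyl group on the amide-type nitrogen gives a 62-fold higher number from compound 1 to compound 4 (1.79 log units; beyond the scatter) in one step, so a large rise at this position is not confined to the two lactam rings seen earlier. Set against the 1-methyl-6-oxopiperidin-3-yl group, it gives a 1.0-fold lower number from compound 3 to compound 4 (0.01 log units; within the scatter) and the two cannot be told apart, whereas against the 1-methyl-2-oxopiperidin-4-yl group it gives a 5.1-fold higher number from compound 2 to compound 4 (0.71 log units; beyond the scatter) and stays clearly separate. No experimental finding at hand accounts for these steps.

The compounds shown leave open whether the methylene link matters, since 1-methylpyrrolidin-3-yl set directly on the amide-type nitrogen would separate the ring from its chain carbon, and whether the methyl on the pyrrolidine nitrogen matters, since the unsubstituted pyrrolidine would test it. They also leave open whether an open-chain amine such as 2-(dimethylamino)ethyl, a morpholine ring or a carboxylic acid at this position would reach a similar level in this assay.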